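One Ring Swap, Carried Over to a Stronger Compound

The source may report more compounds than this note shows. Statements on the series, on what has been measured and on what is new or still open speak of the compounds shown alone.

Compound 1 `COc1ccc(-n2nc(C(=O)Nc3ccc(Oc4ccnc5cc(OCCCN6CCCC6)c(OC)cc45)c(F)c3)c(C)cc2=O)cc1` and compound 2 `COc1ccc(-n2nc(C(=O)Nc3ccc(Oc4ccnc5cc(OCCCN6CCN(C)CC6)c(OC)cc45)c(F)c3)c(C)cc2=O)cc1` differ in a single place: 4-methylpiperazin-1-yl in place of pyrrolidin-1-yl on a saturated chain carbon, three bonds along the chain from an oxygen on an aromatic ring. In a functional assay on A549 cells (Homo sapiens) for inhibition, read by MTT assay, with a stated time of 72 h (a higher number here means a weaker inhibitor, a lower number a stronger inhibitor), compound 1 gives 2770 nM, and compound 2 gives 2200 nM, so the step of a 1.3-fold lower number from compound 1 to compound 2 (0.10 log units; within the scatter) is a small one. Compound 3 `COc1cc2c(Oc3ccc(NC(=O)c4nn(-c5ccc(F)c(F)c5)c(=O)cc4C)cc3F)ccnc2cc1OCCCN1CCCC1` carries the core of compound 1 changed by 3,4-difluorophenyl in place of 4-methoxyphenyl on an aromatic nitrogen; in this assay compound 3 gives 220 nM, a step of a 13-fold lower number from compound 1 to compound 3 (1.10 log units; beyond the scatter). Compound 4 `COc1cc2c(Oc3ccc(NC(=O)c4nn(-c5ccc(F)c(F)c5)c(=O)cc4C)cc3F)ccnc2cc1OCCCN1CCN(C)CC1` applies to compound 3 the same change already seen, (4-methylpiperazin-1-yl in place of pyrrolidin-1-yl on a saturated chain carbon, three bonds along the chain from an oxygen on an aromatic ring), at a place described in the same words: on a saturated chain carbon, three bonds along the chain from an oxygen on an aromatic ring. Because the step of a 1.3-fold lower number from compound 1 to compound 2 (0.10 log units; within the scatter) stayed within the scatter, for compound 4 the expected step is a 1.2-fold lower number from compound 3 to compound 4 (0.06 log units; within the scatter). The estimate for compound 4 in this assay is 190 nM, most likely falling between 90 nM and 400 nM.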

Compound 4, half-maximal inhibitory concentration: 130 nM
Beside the measured number, compound 4's estimate is 1.5-fold (0.16 log units) above it, within the range that was stated.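

In this assay, the swap to 4-methylpiperazin-1-yl from pyrrolidin-1-yl on the 3,4-difluorophenyl core gives a 1.7-fold lower number from compound 3 to compound 4 (0.23 log units; within the scatter), and this agrees with the same swap on the 4-methoxyphenyl core: the same change on two cores in this assay, a 1.3-fold lower number (0.10 log units; within the scatter) from compound 1 to compound 2 and a 1.7-fold lower number (0.23 log units; within the scatter) from compound 3 to compound 4, 1.3-fold (0.13 log units) apart, within the scatter of two such steps. The swap to 3,4-difluorophenyl from 4-methoxyphenyl, now made with 4-methylpiperazin-1-yl on the chain, gives a 17-fold lower number from compound 2 to compound 4 (1.23 log units; beyond the scatter), again matching its earlier step: the same change on two cores in this assay, a 13-fold lower number (1.10 log units; beyond the scatter) from compound 1 to compound 3 and a 17-fold lower number (1.23 log units; beyond the scatter) from compound 2 to compound 4, 1.3-fold (0.13 log units) apart, within the scatter of two such steps. So each change carried over between these two cores with about the same size, but four compounds cannot show that it would do so on any other core or in any other assay.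

On these data alone, it remains open whether another amine on the chain, such as morpholin-4-yl, or a longer chain would fit the same picture. As far as these compounds go, it is also open whether another group on the aromatic nitrogen, such as 4-chlorophenyl, would give a step as large as 3,4-difluorophenyl does.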